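Adding an Acyl Group to Compound 2

The source may hold more compounds than are shown below. What is called first, only, known or untested is meant among the compounds shown, and "the series" means these compounds.

Compound 1 `C/C=C(\C)C(=O)O[C@H]1C[C@@](C)(O)[C@]23C=C[C@](C)([C@@H]2[C@H]2OC(=O)[C@@H](C)[C@@H]21)[C@]1(C3)C(=O)O[C@@H]2[C@H]3C(C)=CC[C@H]3[C@](C)(O)C[C@H](O)[C@H]21`: 9200 nM
Compound 2 `C=C1C(=O)O[C@H]2[C@H]1[C@@H](OC(=O)/C(C)=C/C)C[C@@](C)(O)[C@]13C=C[C@](C)([C@H]21)[C@]1(C3)C(=O)O[C@@H]2[C@H]3C(C)=CC[C@H]3[C@](C)(O)C[C@H](O)[C@H]21`: 7500 nM
Compound 3 `C=C1C(=O)O[C@H]2[C@H]1[C@@H](O)C[C@@](C)(O)[C@]13C=C[C@](C)([C@H]21)[C@]1(C3)C(=O)O[C@@H]2[C@H]3C(C)=CC[C@H]3[C@](C)(O)C[C@H](OC(=O)/C(C)=C\C)[C@H]21`: > 10000 nM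
Compound 4 `C=C1C(=O)O[C@H]2[C@H]1[C@@H](OC(=O)/C(C)=C/C)C[C@@](C)(O)[C@]13C=C[C@](C)([C@H]21)[C@]1(C3)C(=O)O[C@@H]2[C@H]3C(C)=CC[C@H]3[C@](C)(O)C[C@H](OC(=O)/C(C)=C/C)[C@H]21`: not yet measured

In a functional assay on HONE1 cells for cytotoxicity against HONE1 cell line (Homo sapiens), read by MTT assay, with a stated time of 48 h (on this read-out higher numbers stand for weaker inhibition and lower numbers for stronger inhibition), compound 2 gives 7500 nM, and this stands within the scatter of compound 1 at 9200 nM. For compound 3 the result is only a limit, > 10000 nM. Compound 4 differs from compound 2 by (1-methylprop-1-en-1-yl)carbonyl in place of hydrogen on an oxygen on a saturated carbon, with hydroxy going to ((1-methylprop-1-en-1-yl)carbonyl)oxy on a saturated carbon. For the measured compounds named here, no measured pair of compounds shows this change alone, so the estimate is loose, and no shift beyond the scatter is expected in this assay. The expected change is a 1.4-fold lower number from compound 2 to compound 4 (0.13 log units; within the scatter). For compound 4 the estimated value is 5500 nM, with an expected range from 2000 nM to 10000 nM.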

Compound 4, half-maximal inhibitory concentration: 3500 nM
Beside the measured number, compound 4's estimate is 1.6-fold (0.20 log units) above it; low and high end bracket the measured number.
By their numbers in this assay, from the lowest: compound 4; then compounds 2 and 1 (each within the scatter of the next). At a limit, above all of these: compound 3.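

Putting (1-methylprop-1-en-1-yl)carbonyl in place of hydrogen on the oxygen on a saturated carbon gives a 2.1-fold lower number from compound 2 to compound 4 (0.33 log units; beyond the scatter) in this assay. For the compounds shown here, the earlier compounds offered no pair differing in one place, so this is the first sign that the free hydroxy here is not needed for this read-out and that acylating it can move the number modestly. Nothing measured here accounts for the step.

Going by these compounds, whether a shorter acetyl group, a longer acyl chain or an acyl group carrying an amine on this oxygen would shift the number further remains open.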